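Methoxycarbonyl series: phenyl in place of ethyl

This account rests on a few compounds, and the source may have more. Where it says the series, first, only, none or still open, it means among the compounds named here.

Measured so far:
Compound 1 `COC(=O)c1nc(C)n(-c2cccc(C(F)(F)F)c2)n1` — in a functional assay on NPC-TW01 cells (Homo sapiens) for inhibition, read by MTT assay, with a stated time of 72 h (a higher number here means a weaker inhibitor of growth, a lower number a stronger inhibitor of growth), compound 1 gives > 100000 nM
Compound 2 `COC(=O)c1nc(C)n(-c2ccc(Cl)cc2)n1` — compound 2 gives 17500 nM
Compound 3 `CCc1nc(C(=O)OC)nn1-c1ccc(F)cc1` — compound 3 gives 15800 nM

The value of compound 1 is a limit of this assay and not a number (the limit of > 100000 nM in this assay, at which 1 of the 3 values shown sits). Among the two numbers actually measured, compound 3 holds the lower one, but compound 2 sits within the scatter of it, so the two cannot be placed in any order. Going by the values given here, no step between two measured compounds that differ in a single place exists in this set, so nothing measured here tells how a change at the ring carbon shifts the growth inhibition.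

Compound 4 `COC(=O)c1nc(-c2ccccc2)n(-c2ccc(F)cc2)n1` differs from compound 3 in one place: phenyl in place of ethyl on an aromatic carbon. Among the compounds with values here, with no measured step of this kind to lean on, the expectation is for no step beyond the scatter, perhaps a slight lowering of the number. The step from compound 3 to compound 4 is estimated as a 1.3-fold lower number from compound 3 to compound 4 (0.12 log units; within the scatter). Compound 4 is expected to give about 12000 nM in this assay, with a likely range from 3000 nM to 60000 nM.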

Compound 4, concentration for 50% growth inhibition: 15600 nM
Compound 4: the middle estimate sits 1.3-fold (0.11 log units) below what was measured, within the range that was stated.
By their numbers in this assay, from the lowest: compounds 4, 3 and 2 (each within the scatter of the next). At a limit, above all of these: compound 1.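

In this assay the ring carbon between two ring nitrogen atoms now has its first step that differs in one place, and phenyl in place of ethyl gives a 1.0-fold lower number from compound 3 to compound 4 (0.01 log units; within the scatter) as that step. With the fluorophenyl and methoxycarbonyl groups held constant, this position therefore takes phenyl, with 6 heavy atoms against 2 for ethyl, with no change in growth inhibition that can be separated from the scatter. Nothing measured here gives a cause for this result.

Going by these compounds alone, compound 1 remains a limit of the assay at > 100000 nM and has no single-place step to any other compound, so its trifluoromethyl group cannot be assessed. On these data alone, whether an amine or a longer chain such as butyl at this ring carbon, or a carboxylic acid in place of the methoxycarbonyl group, would shift the number beyond the scatter stays open.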